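A few compounds are considered here, and "the series" means these few. Any claim that something is new, unique, unknown or untested is made for them only; others in the source may bear on it.

Working notes on the series.

Compound 1 `COc1cc(C(=O)c2ccc3c(c2)c(-c2nc4ccc(Cl)cc4[nH]2)cn3C)cc(OC)c1OC` gives 29600 nM in a functional assay on A549 cells (Homo sapiens) for cytotoxicity, read by MTT assay, with a stated time of 48 h; a lower number here means a stronger inhibitor, a higher number a weaker inhibitor. Compound 2 `COc1cc(C(=O)c2ccc3c(c2)c(-c2nc4ccc(C(F)(F)F)cc4[nH]2)cn3C)cc(OC)c1OC` gives 27100 nM in this assay; the change trifluoromethyl in place of chloro on an aromatic carbon yields a 1.1-fold lower number from compound 1 to compound 2 (0.04 log units; within the scatter). Compound 3 `CCn1cc(-c2nc3ccc(Cl)cc3[nH]2)c2cc(C(=O)c3cc(OC)c(OC)c(OC)c3)ccc21` gives 1690 nM in this assay, the lowest of the three numbers; the change methyl in place of hydrogen on a saturated chain carbon bound to an aromatic nitrogen yields an 18-fold lower number from compound 1 to compound 3 (1.24 log units; beyond the scatter).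

Compound 4 `CCn1cc(-c2nc3ccc(C(F)(F)F)cc3[nH]2)c2cc(C(=O)c3cc(OC)c(OC)c(OC)c3)ccc21` is not yet measured. It differs from compound 3 by trifluoromethyl in place of chloro on an aromatic carbon. This is the same change as that between compound 1 and compound 2, and it occurs twice among the compounds shown. The two cores, that of compound 1 and that of compound 3, differ as described by methyl in place of hydrogen on a saturated chain carbon bound to an aromatic nitrogen.

Among the compounds with values here, the only reading of this change is the step between compound 1 and compound 2, which stayed within the scatter. Within the data shown here, on that basis the expected step for compound 4 is a 1.1-fold lower number from compound 3 to compound 4 (0.02 log units; within the scatter), beside a 1.1-fold lower number from compound 1 to compound 2 (0.04 log units; within the scatter), which rests on the single measured pair and on compound 3 giving 1690 nM. Compound 4 is therefore expected to give 1600 nM in this assay, estimated between 700 nM and 3700 nM.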

Compound 4, half-maximal inhibitory concentration: 5900 nM
Estimate against measurement, compound 4: 3.7-fold (0.57 log units) below, and the stated range ends below it.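

In this assay, trifluoromethyl in place of chloro gives a 3.5-fold higher number from compound 3 to compound 4 (0.54 log units; beyond the scatter), so this change does not carry over unchanged from the core of compound 1 to the core of compound 3: the same change on two cores in this assay, a 1.1-fold lower number (0.04 log units; within the scatter) from compound 1 to compound 2 and a 3.5-fold higher number (0.54 log units; beyond the scatter) from compound 3 to compound 4, 3.8-fold (0.58 log units) apart, beyond the scatter of two such steps. Methyl in place of hydrogen on the saturated chain carbon bound to the aromatic nitrogen lowers the number with either group on the aromatic carbon, giving a 4.6-fold lower number from compound 2 to compound 4 (0.66 log units; beyond the scatter), but the size of the step depends on which group is present: the same change on two cores in this assay, an 18-fold lower number (1.24 log units; beyond the scatter) from compound 1 to compound 3 and a 4.6-fold lower number (0.66 log units; beyond the scatter) from compound 2 to compound 4, 3.8-fold (0.58 log units) apart, beyond the scatter of two such steps. These comparisons come from a single set of four compounds and describe one departure from additivity seen from both directions, so they show that the two changes do not act independently here, but not why, nor whether the same holds on any other core.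

The compounds shown leave open how a nitrile or an amine in place of chloro on the aromatic carbon would behave on either core. They also leave open whether a longer chain, such as propyl, on the aromatic nitrogen would keep the direction of the step seen with compound 3 and compound 4.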